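The source may report more compounds than this note shows. Statements on the series, on what has been measured and on what is new or still open speak of the compounds shown alone.

Measured so far in an assay on microsomes from intestine for inhibition of acyl-CoA:cholesterol acyltransferase (Oryctolagus cuniculus); a higher number here means a weaker inhibitor, a lower number a stronger inhibitor:
- compound 1 `CCCCCCCC/C=C/CCCCCCCC(=O)Nc1ccc(OC)cc1OC` gives 3000 nM
- compound 2 `CCCCCCCC/C=C/CCCCCCCC(=O)Nc1c(C)cccc1OC` gives 20 nM

Compound 1 holds the highest of these two numbers; its nearest neighbour is compound 2, reached by a 150-fold lower number from compound 1 to compound 2 (2.18 log units; beyond the scatter). Within the data shown here, that single step, which exchanges the whole substitution pattern of the ring on the amide nitrogen while keeping the long unsaturated chain, is the only measured step on this shared core, and it shows that substitution changes on that ring can move the number a long way in this assay.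

Compound 3 `CCCCCCCC/C=C/CCCCCCCC(=O)Nc1c(O)cc(OC)cc1OC` keeps both methoxy groups of compound 1 and differs from it by hydroxy in place of hydrogen on an aromatic carbon. Among the measured compounds shown here, no measured step introduces a hydroxy group, so the size of a 150-fold lower number from compound 1 to compound 2 (2.18 log units; beyond the scatter) is only an indirect guide: it shows that altering this ring can lower the number strongly, but the group added and its place differ from that step. For compound 3 a moderate drop is therefore expected, a 5.0-fold lower number from compound 1 to compound 3 (0.70 log units; beyond the scatter), with wide uncertainty. For compound 3 the expected value is 600 nM, in the range 100 nM to 3000 nM.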

Compound 3, half-maximal inhibitory concentration: 150 nM
The estimate for compound 3 lay 4.0-fold (0.60 log units) above the measured number; the range from low to high includes it.
By their numbers in this assay, from the lowest: compound 2; then compound 3; then compound 1.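

In this assay adding one hydroxy group to compound 1, on an aromatic carbon ortho to a large group and meta to two methoxy groups, gives a 20-fold lower number from compound 1 to compound 3 (1.30 log units; beyond the scatter) and so shows that this single place on the ring matters. The change adds only one heavy atom and leaves both methoxy groups in place, yet the step is large and lies beyond the scatter. Nothing available explains why this hydroxy group has such an effect.

Still open, going by these compounds, is whether the hydroxy group itself is needed, or whether a methoxy group, an amine or a fluorine atom at the same place would lower the number as well. On these data alone, it is also open whether a hydroxy group would have a similar effect on the ring of compound 2, which carries a different set of groups.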